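A few compounds are considered here, and "the series" means these few. Any claim that something is new, unique, unknown or untested is made for them only; others in the source may bear on it.

In a functional assay on IMR-32 cells (Homo sapiens) for antiproliferative activity, with a stated time of 72 h (a lower number here means a stronger inhibitor, a higher number a weaker inhibitor), compound 2 `Cc1cc(C)cc(C(=O)N(CCC(=O)NCc2ccccc2)Cc2ccc(C(=O)NO)cc2)c1` stands highest of the two numbers at 1390 nM against compound 1 `Cc1ccc(NC(=O)CCN(Cc2ccc(C(=O)NO)cc2)C(=O)c2cc(C)cc(C)c2)cc1` at 210 nM in the same read-out. Compound 3 `COc1ccc(C(=O)N(CCC(=O)NCc2ccccc2)Cc2ccc(C(=O)NO)cc2)cc1` differs from compound 2 on a carbonyl carbon, with 4-methoxyphenyl in place of 3,5-dimethylphenyl (4-methoxyphenyl in place of 3,5-dimethylphenyl on a carbonyl carbon). Among the measured compounds shown here, the only measured step of a 6.6-fold higher number from compound 1 to compound 2 (0.82 log units; beyond the scatter) lies beyond the scatter but sits on an amide-type nitrogen and so says little about this change. No shift beyond the scatter is therefore expected, with a 1.2-fold lower number from compound 2 to compound 3 (0.06 log units; within the scatter) as the estimated step. In this assay compound 3 is expected at 1200 nM with an estimated range from 450 nM to 3200 nM in this read-out.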

Compound 3, half-maximal inhibitory concentration: 1090 nM
Compound 3: the middle estimate sits 1.1-fold (0.04 log units) above what was measured; low and high end bracket the measured number.
By their numbers in this assay, from the lowest: compound 1; then compounds 3 and 2 (each within the scatter of the next).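

In this assay, the step on the carbonyl carbon is a 1.3-fold lower number from compound 2 to compound 3 (0.11 log units; within the scatter), so 4-methoxyphenyl, with its one hydrogen-bond acceptor, stands in for 3,5-dimethylphenyl with no shift beyond the scatter. Among the compounds shown here, the earlier step spoke only to the amide-type nitrogen; this one gives the first reading at the carbonyl carbon. No evidence at hand accounts for this result. From the compounds shown here alone, whether the same exchange holds with the 4-methylphenyl of compound 1 on the amide-type nitrogen stays open. So does how an amine or a carboxylic acid in place of the methoxy group would fare.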